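A few compounds are considered here, and "the series" means these few. Any claim that something is new, unique, unknown or untested is made for them only; others in the source may bear on it.

Compound 1 `COc1ccccc1/C=c1/[nH]c(=O)/c(=C\c2cccc(Cl)c2Cl)[nH]c1=O` gives "not active" (no number reported) in a functional assay on MCF7 cells (Homo sapiens) for cytotoxicity, read by CCK-8 assay, with a stated time of 72 h; a lower number here means a stronger inhibitor, a higher number a weaker inhibitor.
Compound 2 `C=CCn1c(=O)/c(=C\c2ccccc2Cl)[nH]c(=O)/c1=C\c1ccccc1OC` gives 4700 nM in this assay.

Within the data shown here, compound 2 carries the only number reported in this assay; compound 1 stands beside it without one. Compound 3 `C=CCn1c(=O)/c(=C\c2ccccc2OC)[nH]c(=O)/c1=C\c1ccccc1OC` differs from compound 2 by methoxy in place of chloro on an aromatic carbon. Among the measured compounds shown here, no measured pair isolates this change, so its size is not fixed by the data; a small shift toward weaker inhibition, barely beyond the scatter, is expected. Compound 3 is accordingly estimated at 7000 nM, with a range from 2000 nM to 25000 nM. The expected step is a 1.5-fold higher number from compound 2 to compound 3 (0.17 log units; within the scatter).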

Compound 3, half-maximal inhibitory concentration: 41100 nM
Compound 3: middle estimate off by 5.9-fold (0.77 log units), on the low side; measured number above the stated range.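

Methoxy in place of chloro on this aromatic carbon gives an 8.7-fold higher number from compound 2 to compound 3 (0.94 log units; beyond the scatter) in this assay and thereby supplies the first measured size for this change. The step lies beyond the scatter, so this place responds to the group it carries, and chloro gives the lower number of this pair. Nothing measured here accounts for the shift. As far as these compounds go, whether fluoro, methyl or an amine at the same place would give a lower or higher number stays open. So does whether methoxy in place of chloro gives a step of similar size elsewhere on the shared core.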